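The compounds below may be only part of what the source reports. "The series", "measured", "known", "first", "only" and "open" are said of these compounds alone.

In a functional assay on L1210 cells (Mus musculus) for cytotoxicity, read by MTT assay, with a stated time of 24 h (on this read-out higher numbers stand for weaker inhibition and lower numbers for stronger inhibition), the measured compounds are these
- compound 1 `COc1cc(C(=O)/C=C/c2ccc3ccccc3c2)cc(OC)c1OC` gives 26000 nM in this assay
- compound 2 `COc1cc(C(=O)/C=C/c2ccc(Cl)cc2)cc(OC)c1OC` gives 44500 nM in this assay
- compound 3 `COc1cc(C(=O)/C=C/c2ccc(C)cc2)cc(OC)c1OC` gives 50500 nM in this assay

These three numbers lie within the usual scatter of one another, so compound 2 cannot be ranked apart from compound 1 or compound 3. Compound 4 `CCCCOc1ccc(/C=C/C(=O)c2cc(OC)c(OC)c(OC)c2)cc1` has not been measured yet. The change from compound 2 to compound 4 is butoxy in place of chloro on an aromatic carbon and in words it is butoxy in place of chloro on an aromatic carbon, para to a large group.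

Going by the values given here, only one measured step touches that chloro. Methyl in place of chloro on an aromatic carbon gives a 1.1-fold higher number from compound 2 to compound 3 (0.05 log units; within the scatter) and so shows no change beyond the scatter. Among the compounds with values here, no measured compound carries butoxy, and this group is larger than methyl, so that single step is only a weak guide. Going by it, with compound 3 at 50500 nM in the same range as compound 2, no step beyond the scatter is expected in this assay for compound 4. The expected change is a 1.1-fold lower number from compound 2 to compound 4 (0.05 log units; within the scatter) and it remains an estimate. For compound 4 the estimated value is 40000 nM with an expected range from 16000 nM to 90000 nM in this measurement.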

Compound 4, half-maximal inhibitory concentration: > 100000 nM
Compound 4 gave a limit, no number (the forecaster's own chance of this, stated with the estimate: 10%); at least 2.5-fold (0.39 log units) between middle value and limit.
By their numbers in this assay, from the lowest: compounds 1, 2 and 3 (each within the scatter of the next). At a limit, above all of these: compound 4.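

In this assay compound 4 gives a limit and not a number: the limit of > 100000 nM in this assay, at which 1 of the 4 values shown sits. Going by these compounds alone, exchanging the chloro for butoxy on an aromatic carbon, para to a large group, gives an at least 2.2-fold higher number from compound 2 to compound 4 (0.35 log units; beyond the scatter), and this is the first step at this position that clears the scatter, whereas methyl in place of chloro gave only a 1.1-fold higher number from compound 2 to compound 3 (0.05 log units; within the scatter). Butoxy in place of methyl gives an at least 1.9-fold higher number from compound 3 to compound 4 (0.29 log units; that floor lies within the scatter), so the comparison with compound 2 is the one that shows a real loss of inhibition, and this position does not accept every replacement of chloro without a change in the read-out.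

The true size of that loss stays unknown, since the comparison ends at a limit, and the compounds shown cannot separate the part played by the oxygen of butoxy from the part played by its chain, as they hold no methoxy, no ethoxy and no plain butyl group at this position. On these data alone, whether an amine or a carboxylic acid on this carbon would keep the number near that of compound 2 also stays open.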